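Chloro for fluoro: expectation for compound 4

The source may hold more compounds than are shown below. What is called first, only, known or untested is meant among the compounds shown, and "the series" means these compounds.

Measured so far in a functional assay on PC-3 cells (Homo sapiens) for antiproliferative activity, read by MTT assay; a lower number here means a stronger inhibitor, a higher number a weaker inhibitor:
compound 1 `CNC(=O)c1ccc(Oc2cccc(NC(=S)Nc3ccc(F)cc3)c2)nc1`: 32700 nM
compound 2 `CNC(=O)c1ccc(Oc2cccc(NC(=S)Nc3ccc(OC)cc3)c2)nc1`: > 100000 nM
compound 3 `CNC(=O)c1ccc(Oc2cccc(NC(=S)Nc3ccc(Cl)c(C(F)(F)F)c3)c2)nc1`: 1980 nM

Compound 1 gives the highest number among the measured values; the nearest is compound 3, whose number is lower by the margin shown, beyond the scatter. For compound 2 the result is a limit of this assay, not a number (the limit of > 100000 nM in this assay, at which 1 of the 3 values shown sits).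

Compound 4 `CNC(=O)c1ccc(Oc2cccc(NC(=S)Nc3ccc(Cl)cc3)c2)nc1` is not yet measured. It differs from compound 1 as follows: chloro in place of fluoro on an aromatic carbon.

Going by the values given here, the only measured step from compound 1 is an at least 3.0-fold higher number from compound 1 to compound 2 (0.48 log units; beyond the scatter), which exchanges the same fluoro for a methoxy and ends at a limit. Among the compounds with values here, compound 3, which carries a chloro together with a trifluoromethyl on that ring, gives the lowest number of the three, but it differs from compound 1 in two places, so no single step to it can be read. Taken together, a halogen-for-halogen exchange at the same position is expected to move the number modestly, and more likely downward than upward, so the step from compound 1 to compound 4 is estimated at a 2.7-fold lower number from compound 1 to compound 4 (0.44 log units; beyond the scatter).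

For compound 4, this assay is expected to give about 12000 nM, with the range 4000 nM to 36000 nM.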

Compound 4, half-maximal inhibitory concentration: 28400 nM
Compound 4: the middle estimate sits 2.4-fold (0.37 log units) below what was measured, and the stated range covers the measured number.
By their numbers in this assay, from the lowest: compound 3; then compounds 4 and 1 (each within the scatter of the next). At a limit, above all of these: compound 2.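

In this assay, chloro in place of fluoro on this aromatic carbon, para to a large group, gives a 1.2-fold lower number from compound 1 to compound 4 (0.06 log units; within the scatter), so the two halogens cannot be told apart here, and the identity of the halogen at this position does not separate these compounds. The trifluoromethyl can now be read on its own with the chloro held constant: hydrogen in its place gives a 14-fold higher number from compound 3 to compound 4 (1.16 log units; beyond the scatter), so the low number of compound 3 goes with the added trifluoromethyl and not with the chloro alone. Chloro in place of methoxy gives an at least 3.5-fold lower number from compound 2 to compound 4 (0.54 log units; beyond the scatter), but that size is only a bound, as the starting value of this step is a limit and not a number: the limit of > 100000 nM in this assay, at which 1 of the 4 values shown sits.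

The compounds shown leave open whether a trifluoromethyl without the chloro would keep the low number of compound 3. They also leave open whether a bromo, a nitrile or an amine on this aromatic carbon would fall with the two halogens or with the methoxy.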